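The compounds below may be only part of what the source reports. "The series", "measured", "known", "first", "only" and "open" are said of these compounds alone.

Going by the values given here, compound 2 `COc1cc2[nH]c(C)c(Br)c(=O)c2cc1Cl` is the one member of the pair that carries a number in a physicochemical assay for lipophilicity, at pH 7.4 (on this read-out higher numbers stand for higher lipophilicity and lower numbers for lower lipophilicity), where compound 2 gives 0. Compound 1 `CCCCCCCc1c(C)[nH]c2cc(OC)c(Cl)cc2c1=O` is reported in this assay only as a limit, < 3.83. The step that the limit leaves unreadable from compound 1 to compound 2 therefore cannot be read in size because the limit of < 3.83 in this assay, at which 1 of the 2 values shown sits, hides how far compound 1 lies from compound 2. Compound 3 `CCCCC/C=C/c1c(C)[nH]c2cc(OC)c(Cl)cc2c1=O` differs from compound 2 by hept-1-en-1-yl in place of bromo on an aromatic carbon. Among the compounds with values here, the only measured step that touches this position, a step that the limit leaves unreadable from compound 1 to compound 2, is unreadable, so no measured size can be carried over to the new change, and the expectation rests on the number of compound 2 and the limit of compound 1 alone. On that basis the step to compound 3 is expected to be a number 3.00 log units higher from compound 2 to compound 3 (beyond the scatter). Compound 3 is accordingly estimated at 3 in this assay, within a range from 1.5 to 3.8.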

Compound 3, distribution coefficient: 3.57
Beside the measured number, compound 3's estimate is 0.57 log units below it; the measured number falls inside the stated range.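

In this assay, this position now has its first readable step: with hept-1-en-1-yl in place of bromo on an aromatic carbon, the read-out gives a number 3.57 log units higher from compound 2 to compound 3 (beyond the scatter). The earlier pair gave no size for any change at this position, whereas this step is large and shows that the group held here can shift the read-out well beyond the scatter. The steps that touch compound 1 still cannot be read, as compound 1 is reported only as a limit: the limit of < 3.83 in this assay, at which 1 of the 3 values shown sits.

The compounds shown therefore leave open whether the double bond of hept-1-en-1-yl makes any difference compared with the saturated heptyl chain. They also leave open how a shorter chain, an amine or a carboxylic acid at this position would read.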